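Replacing a Halophenyl with Benzimidazolyl on the Triazole

This account rests on a few compounds, and the source may have more. Where it says the series, first, only, none or still open, it means among the compounds named here.

The series shares one core, seen in compound 1 `CN(CCNCc1cn(-c2ccc(F)cc2)nn1)CCNc1ccnc2cc(Cl)ccc12` and compound 2 `CN(CCNCc1cn(-c2ccc(Br)cc2)nn1)CCNc1ccnc2cc(Cl)ccc12`, which differ only in the group on the aromatic nitrogen of the triazole ring. In a functional assay on BXPC-3 cells (Homo sapiens) for antiproliferative activity, read by sulforhodamine B assay, with a stated time of 72 h (a higher number here means a weaker inhibitor, a lower number a stronger inhibitor), compound 1 gives 12000 nM. In the same assay compound 2 gives 7900 nM. Among the compounds with values here, the one measured step is a 1.5-fold lower number from compound 1 to compound 2 (0.18 log units; within the scatter), so the two compounds cannot be ranked against each other. Compound 2 therefore simply stands beside compound 1 on the numbers seen so far.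

Compound 3 `CN(CCNCc1cn(-c2nc3ccccc3[nH]2)nn1)CCNc1ccnc2cc(Cl)ccc12` carries the change (1H-benzimidazol-2-yl in place of 4-bromophenyl on an aromatic nitrogen). Within the data shown here, no measured step in this set concerns a swap of an aryl group for a heteroaryl group on that nitrogen; the only known step exchanges one halogen for another and stays within the scatter. There is thus no direct guide to the size or direction of the move. Compound 3 is expected to land at 8000 nM, within a range from 2000 nM to 32000 nM. The expected step is a 1.0-fold higher number from compound 2 to compound 3 (0.01 log units; within the scatter), with no confident direction beyond the scatter.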

Compound 3, half-maximal inhibitory concentration: 16000 nM
The estimate for compound 3 lay 2.0-fold (0.30 log units) below the measured number, and the stated range covers the measured number.
By their numbers in this assay, from the lowest: compounds 2, 1 and 3 (each within the scatter of the next, the first and the last beyond it).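

Within the data shown here, replacing 4-bromophenyl with 1H-benzimidazol-2-yl on the aromatic nitrogen gives a 2.0-fold higher number from compound 2 to compound 3 (0.31 log units; beyond the scatter), the first step in the set to pass the scatter, although only modestly, and the first change here to go beyond exchanging one halogen for another. Against 4-fluorophenyl, the same group gives a 1.3-fold higher number from compound 1 to compound 3 (0.12 log units; within the scatter), so in this assay it separates from only one of the two halophenyl groups, and this position accepts an added five-membered ring bearing a hydrogen-bond donor without a large shift in the number. Nothing measured here accounts for the modest step seen against 4-bromophenyl.

The compounds shown leave open whether the benzimidazole hydrogen-bond donor matters at all, a question that a 1-methylbenzimidazol-2-yl group on the same nitrogen would address directly. They also leave open how this position responds to groups of a different kind, such as a simple pyridin-2-yl ring, an unsubstituted phenyl or a phenyl ring carrying a carboxylic acid, since every group seen so far is a halophenyl or 1H-benzimidazol-2-yl.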